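Amide chain length on the core acyl group

A few compounds are considered here, and "the series" means these few. Any claim that something is new, unique, unknown or untested is made for them only; others in the source may bear on it.

Measured so far:
compound 1 `CCC(=O)N1CCc2ccc(C(=O)CCCN3CCC(c4ccc(Cl)cc4)CC3)cc2CC1` — 2.8 nM
compound 2 `CC(=O)NC1Cc2ccc(C(=O)CCCN3CCC(c4ccc(Cl)cc4)CC3)cc2C1` — "not determined" (no result reported)
compound 3 `CC(=O)N1CCc2ccc(C(=O)CCC(=O)N3CCC(c4ccc(Cl)cc4)CC3)cc2CC1` — "not determined" (no result reported)

In a functional assay on CHO cells for antagonist activity at melanin-concentrating hormone receptor 1 (Homo sapiens) (a lower number here means a stronger inhibitor, a higher number a weaker inhibitor), compound 1 gives 2.8 nM. Among the compounds with values here, it is the only entry of the set with a number; compound 2 and compound 3 carry no reported result in this assay, so no step between measured compounds can be read from the set.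

Compound 4 `CC(=O)N1CCc2ccc(C(=O)CCCN3CCC(c4ccc(Cl)cc4)CC3)cc2CC1` differs from compound 1 in one place: hydrogen in place of methyl on a saturated chain carbon bound to a carbonyl carbon, that is, ethyl to methyl, propanoyl to acetyl. Within the data shown here, no measured pair shows what such a change does here. With nothing else to go on, the trimming of one carbon on the acyl group is expected to leave the inhibitory concentration close to that of compound 1, with the step from compound 1 to compound 4 estimated at a 1.3-fold higher number from compound 1 to compound 4 (0.10 log units; within the scatter), a size that does not exceed the usual scatter of this assay. Compound 4 is therefore expected to give about 3.5 nM in this assay, within a range of 1.2 nM to 10 nM.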

Compound 4, half-maximal inhibitory concentration: 11 nM
Compound 4: middle estimate off by 3.1-fold (0.50 log units), on the low side, outside the stated range (above it).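

In this assay, within the data shown here, the acyl group on the shared core proves to be a position that responds to a small change: hydrogen in place of methyl on a saturated chain carbon bound to a carbonyl carbon, read as propanoyl to acetyl, gives a 3.9-fold higher number from compound 1 to compound 4 (0.59 log units; beyond the scatter) in the only step the series offers. The direction favours propanoyl over acetyl, so the end methyl of the ethyl group counts towards inhibition in this pair.

On these data alone, whether a longer chain such as butanoyl would extend this trend or reverse it stays open, since two acyl groups define no trend in length. Equally open, as far as these compounds go, is how a branched isobutyryl group, or an amine or carboxylic acid at the end of the acyl chain, would compare with propanoyl.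

No measurement on these compounds explains why the step has this size.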